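Removing a Chloro Group From a Cytotoxicity Tolerance Series

This account rests on a few compounds, and the source may have more. Where it says the series, first, only, none or still open, it means among the compounds named here.

Compound 1 `CCN(CC)CN1C(=O)/C(=N/NC(=S)Nc2ccccc2)c2cc(Cl)ccc21` was examined in an ADME assay on MDCK cells (Canis lupus familiaris) for cytotoxicity; a higher number here means that more compound is tolerated, a lower number that less compound is tolerated. In this assay compound 1 gives >= 800 nM, a limit of the assay rather than a number. Compound 2 `CCN(CC)CN1C(=O)/C(=N/NC(=S)Nc2ccc(Cl)cc2)c2ccccc21` shares the same core but carries its chloro elsewhere. In this assay compound 2 gives 800 nM. The two results therefore sit at the same point, and with the limit of >= 800 nM in this assay, at which 1 of the 2 values shown sits, compound 1 is placed only at the boundary of what the assay reports, not at a fixed number.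

Compound 3 `CCN(CC)CN1C(=O)/C(=N/NC(=S)Nc2ccccc2)c2ccccc21` has not yet been measured. It differs from compound 1 by hydrogen in place of chloro on an aromatic carbon. Among the compounds with values here, no pair of measured compounds differing in a single place is available, so the data give no direction for such a change. In this assay the expectation is that the step from compound 1 to compound 3 stays within the scatter of repeated measurements, with a number no higher from compound 1 to compound 3 (the limit leaves the size open). Compound 3 is accordingly estimated at 800 nM, with an expected range from 400 nM to 1600 nM.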

Compound 3, minimum cytotoxic concentration: 800 nM
For compound 3 middle estimate and measured number coincide at the digits printed, and the stated range covers the measured number.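

With compound 3 the series gains its first comparisons that differ in one place, both of them hydrogen in place of chloro on an aromatic carbon. For the chloro that compound 2 carries elsewhere in the molecule, this assay shows no change at the digits printed from compound 2 to compound 3 (within the scatter) once it is gone, so a compound with no chloro at all is tolerated within the scatter of that chlorinated compound. On the aromatic carbon meta to a fused ring and para to a fused ring, the change gives a number no higher from compound 1 to compound 3 (the limit leaves the size open) and so supplies a direction, though not a size that can be read. The value of compound 1 is a limit of the assay, and this position therefore stays less well defined than the other one: the limit of >= 800 nM in this assay, at which 1 of the 3 values shown sits.

On these data alone, how far the number of compound 1 lies from that of compound 3 remains open, so the chloro on this aromatic carbon cannot yet be given a size of effect. Also open, as far as these compounds go, is what a methoxy group or a carboxylic acid would do on the same carbon, and whether another amine in place of the diethylamino group would shift the reading.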